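Lengthening the chain in a propargylamine series

This account rests on a few compounds, and the source may have more. Where it says the series, first, only, none or still open, it means among the compounds named here.

In an assay on BTI cells for inhibition of Amine oxidase [flavin-containing] B (Homo sapiens), read by fluorescence and Amplex Red, with a stated time of 15 min (a higher number here means a weaker inhibitor, a lower number a stronger inhibitor), the measured compounds are:
Compound 3, `C#CCN(C)CCCCOc1ccc(C(C)=O)cc1`, gives 56.5 nM.
Compound 1, `C#CCN(C)CCCCOc1ccc2c(c1)CCCC2=O`, gives 72.5 nM.
Compound 2, `C#CCN(C)CCCCCCCCOc1ccc2c(c1)OCCC2=O`, gives 422 nM.

Compound 3 has the lowest number of the three. Compound 1 sits within the scatter of compound 3, so the two cannot be ranked, while compound 2 lies beyond the scatter at a higher number. Compound 4, `C#CCN(C)CCCCCCOc1ccc(C(C)=O)cc1`, has not yet been measured. It differs from compound 3 by 2-(methyl(propargyl)amino)ethyl in place of methyl(propargyl)amino on a saturated chain carbon, four bonds along the chain from an oxygen on an aromatic ring, that is, a longer saturated chain. Going by the values given here, no measured pair shows this change on its own. Compound 2 carries the longest chain and the highest number, but its core also differs, so it is only a loose hint. A small step to a weaker value, near the edge of the scatter, is expected a 2.1-fold higher number from compound 3 to compound 4 (0.33 log units; beyond the scatter). Compound 4 is estimated at 120 nM, ranging from 40 nM to 400 nM.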

Compound 4, half-maximal inhibitory concentration: 20.4 nM
Compound 4: middle estimate off by 5.9-fold (0.77 log units), on the high side; the whole stated range lies above it.
By their numbers in this assay, from the lowest: compound 4; then compounds 3 and 1 (each within the scatter of the next); then compound 2.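

Taken alone, the longer chain strengthens inhibition in this assay: swapping methyl(propargyl)amino for 2-(methyl(propargyl)amino)ethyl gives a 2.8-fold lower number from compound 3 to compound 4 (0.44 log units; beyond the scatter) and this modest step lies beyond the scatter. Going by these compounds alone, it is the first reading of chain length with nothing else changed, and this position clearly tolerates the added length. Nothing available explains the gain. On these data alone, whether a still longer chain on the core of compound 4 would extend the gain or reverse it stays open. So does the effect of replacing the propargyl group on the amine with a plain methyl group.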